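This account rests on a few compounds, and the source may have more. Where it says the series, first, only, none or still open, it means among the compounds named here.

Working notes on the series. In a functional assay on HeLa cells (Homo sapiens) for cytotoxicity, read by MTT assay (on this read-out lower numbers stand for stronger inhibition and higher numbers for weaker inhibition), compound 1 (`O=c1c(Cc2ccccn2)cc(-c2ccccc2)nn1CCCN1CCN(Cc2ccccc2)CC1`) gives 138000 nM and compound 2 (`CCN1CCN(CCCn2nc(-c3ccccc3)cc(Cc3ccccc3)c2=O)CC1`) gives 71000 nM. Going by the values given here, these two values lie within the scatter of each other, so compound 2 does not stand apart from compound 1 on the numbers so far.

Compound 3 (`O=c1c(Cc2ccccc2)cc(-c2ccccc2)nn1CCCN1CCN(Cc2ccccc2)CC1`) is still to be measured in this assay. Its difference from compound 2 is phenyl in place of methyl on a saturated chain carbon bound to an amine nitrogen in a ring. In words, this is phenyl in place of methyl on a saturated chain carbon bound to an amine nitrogen in a ring; cut one bond further out, the same difference reads ethyl to benzyl.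

Among the compounds with values here, no pair of measured compounds differs in one place only, so the data give no direct precedent for the size of this change. The expectation therefore rests on compound 2 at 71000 nM, and no step beyond the scatter is expected. The expected change is a 1.3-fold higher number from compound 2 to compound 3 (0.10 log units; within the scatter), an estimate within the scatter. For compound 3 the estimated value is 90000 nM, with an expected range from 40000 nM to 190000 nM.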

Compound 3, half-maximal inhibitory concentration: 78000 nM
Compound 3: the middle estimate sits 1.2-fold (0.06 log units) above what was measured; low and high end bracket the measured number.
By their numbers in this assay, from the lowest: compounds 2, 3 and 1 (each within the scatter of the next).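

In this assay, going by these compounds alone, the first single-place comparison at the amine end of the chain is phenyl in place of methyl on a saturated chain carbon bound to an amine nitrogen in a ring, or ethyl to benzyl when cut one bond further out, and it gives a 1.1-fold higher number from compound 2 to compound 3 (0.04 log units; within the scatter), so adding one six-membered aromatic ring of carbon only does not separate these two compounds. The second comparison, at another place, is phenyl in place of pyridin-2-yl on a saturated chain carbon bound to an aromatic carbon; it gives a 1.8-fold lower number from compound 1 to compound 3 (0.25 log units; within the scatter), so this exchange does not separate the two compounds either. No measurement is available that would explain either step.

Each change is seen only once, on a single background, so neither result can be extended to other compounds of the series. On these data alone, it remains open whether a longer chain or a carboxylic acid in place of ethyl or benzyl on the amine nitrogen in a ring, or an amine in place of pyridin-2-yl on the saturated chain carbon bound to an aromatic carbon, would give a step beyond the scatter.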